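Methoxy for Acetamido: Expected Solubility of Compound 4

The compounds below may be only part of what the source reports. "The series", "measured", "known", "first", "only" and "open" are said of these compounds alone.

Three compounds have been measured in a physicochemical assay for solubility; on this read-out higher numbers stand for higher solubility and lower numbers for lower solubility:

compound 1, `Cc1c2c(n3c1CCCNC[C@H](C)Nc1cc-3ccc1C(N)=O)CC(C)(C)CC2=O`, with > 100 ug/mL
compound 2, `CC(=O)N1CCc2c(C)c3c(n2-c2ccc(C(N)=O)c(c2)N[C@@H](C)CC1)CC(C)(C)CC3=O`, with 19 ug/mL
compound 3, `CC(=O)NCCN1CC[C@H](C)Nc2cc(ccc2C(N)=O)-n2c(c(C)c3c2CC(C)(C)CC3=O)CC1=O`, with > 100 ug/mL

For compound 3 the assay reports only a limit, > 100 ug/mL, and not a number. The same is true for compound 1, whose result of > 100 ug/mL is also a limit. Compound 2 is the only one of the three that gives a number, 19 ug/mL. Among these three compounds no pair differs in a single place, so no step between measured compounds can be read directly; what is known is the limit of > 100 ug/mL in this assay, at which 2 of the 3 values shown sit, which leaves compound 3 at the upper edge of what this assay reports.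

Compound 4, `COCCN1CC[C@H](C)Nc2cc(ccc2C(N)=O)-n2c(c(C)c3c2CC(C)(C)CC3=O)CC1=O`, is the compound to be measured next. It differs from compound 3 in one place: methoxy in place of acetamido on a saturated chain carbon, two bonds along the chain from an amide-type nitrogen in a ring.

Within the data shown here, with no measured step to lean on, a small change is expected, and the expected step from compound 3 to compound 4 is a number no higher from compound 3 to compound 4 (the limit leaves the size open), which does not go beyond the usual scatter. Compound 4 is therefore estimated at 100 ug/mL, within a range from 40 ug/mL to 200 ug/mL, and it may well again come back only as a limit.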

Compound 4, solubility: > 100 ug/mL
Compound 4: only a limit was reported; the forecaster's own chance of this, stated with the estimate: 55%; the middle value lies on the limit itself.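

In this assay compound 4 gives > 100 ug/mL, which is a limit and not a number. Among these compounds, compound 3 also stands at a limit, so no step between compound 3 and compound 4 can be read. The compounds shown leave open whether methoxy in place of acetamido changes the result in this assay at all, and the values give only this: the limit of > 100 ug/mL in this assay, at which 3 of the 4 values shown sit.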